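The source may report more compounds than this note shows. Statements on the series, on what has been measured and on what is new or still open speak of the compounds shown alone.

Compound 1 `Cc1cccc(-c2nn(-c3ccccc3)cc2C(Nc2nc3ccccc3s2)c2c(O)ccc3ccccc23)c1`: 18500 nM
Compound 2 `COc1ccc2nc(NC(c3cn(-c4ccccc4)nc3-c3ccc(Cl)cc3)c3c(O)ccc4ccccc34)sc2c1`: 34500 nM

Both values come from a functional assay on A549 cells (Homo sapiens) for antiproliferative activity, read by MTT assay, with a stated time of 48 h; a higher number here means a weaker inhibitor, a lower number a stronger inhibitor. There, compound 2 gives 34500 nM, which lies within the usual scatter of compound 1 at 18500 nM, so these two numbers cannot be ranked against each other.

The next compound, compound 3 `COc1ccc2nc(NC(c3cn(-c4ccccc4)nc3-c3cccc([N+](=O)[O-])c3)c3c(O)ccc4ccccc34)sc2c1`, keeps everything in compound 2 except one group. It has 3-nitrophenyl in place of 4-chlorophenyl on an aromatic carbon.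

The two measured compounds differ from each other in more than one place, so no measured single change can serve as a guide to this swap. For the measured compounds named here, the only evidence is the range of the two values themselves, and nothing in them points to a particular direction. No step beyond the scatter is therefore expected in this assay. The expected result is a 1.4-fold lower number from compound 2 to compound 3 (0.14 log units; within the scatter), a change too small to tell apart from repeat measurement. For compound 3, the estimated value is 25000 nM, with an expected range from 10000 nM to 60000 nM.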

Compound 3, half-maximal inhibitory concentration: 52200 nM
Beside the measured number, compound 3's estimate is 2.1-fold (0.32 log units) below it, within the range that was stated.
By their numbers in this assay, from the lowest: compounds 1, 2 and 3 (each within the scatter of the next, the first and the last beyond it).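

In this assay, for the compounds shown here, putting 3-nitrophenyl in place of 4-chlorophenyl on an aromatic carbon of a five-membered aromatic ring with 2 nitrogen gives a 1.5-fold higher number from compound 2 to compound 3 (0.18 log units; within the scatter), the first single change that can be read at this position. The swap keeps one six-membered aromatic ring of carbon only, while the entering group has 2 hydrogen-bond acceptors and the leaving group has 0, and this exchange does not shift the number beyond the scatter. No measurement of any property of these two groups accompanies the result, so the data offer no explanation for it.

Going by these compounds alone, this single pair shows only that one exchange of substituted phenyl groups leaves the reading within the scatter, and it does not establish a rule for other groups at this position. Going by these compounds, what happens with a group of a different kind here, such as an amine or a carboxylic acid on the phenyl ring, or a saturated ring or a longer chain in place of that ring, remains open.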